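The compounds below may be only part of what the source reports. "The series", "measured", "known", "first", "only" and "open" are said of these compounds alone.

Measured in a functional assay on HCT-116 cells (Homo sapiens) for cytotoxicity, with a stated time of 3 days; on this read-out higher numbers stand for weaker inhibition and lower numbers for stronger inhibition:
- compound 1 `C=Cc1nc2ccccc2n1C`: 9500 nM
- compound 2 `CC#Cc1nc2ccccc2s1`: > 40000 nM (a limit, not a number)
- compound 3 `C=Cc1nc(C(=O)OCC)cs1`: > 40000 nM (a limit, not a number)

Of these, only compound 1 gives a number in this assay. Compound 2 and compound 3 stand at the limit of > 40000 nM in this assay, at which 2 of the 3 values shown sit. Compound 3 also bears a vinyl group and still gives only a limit, so the data do not tie the activity of compound 1 to that group alone.

Next in the series is compound 4 `Cn1cnc2ccccc21`, not yet measured. Relative to compound 1 it has hydrogen in place of vinyl on an aromatic carbon, between two ring nitrogen atoms (hydrogen in place of vinyl on an aromatic carbon). Among the compounds with values here, no measured pair isolates this change, so its size can only be estimated. Within the data shown here, the expectation rests on compound 1, at 9500 nM, as the sole number in the set. The other measured compounds give only a limit of the assay. A step toward weaker inhibition, modestly beyond the usual scatter, is therefore expected: the estimated change is a 2.9-fold higher number from compound 1 to compound 4 (0.47 log units; beyond the scatter). A limit rather than a number is also a real possibility. For compound 4 the expected value is 28000 nM, with an estimated range of 11000 nM to 70000 nM.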

Compound 4, half-maximal inhibitory concentration: > 40000 nM
Compound 4 was reported as a limit; the forecaster's own chance of this, stated with the estimate: 50%; middle value at least 1.4-fold (0.15 log units) away from the limit.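

In this assay, the first pair differing in one place gives an at least 4.2-fold higher number from compound 1 to compound 4 (0.62 log units; beyond the scatter), with hydrogen in place of vinyl on an aromatic carbon, between two ring nitrogen atoms. Compound 3 had already shown that a vinyl group alone does not secure a measurable value, and this pair adds the converse for the core of compound 1: without the vinyl group at this position, it no longer gives a number. The value of compound 4, > 40000 nM, is a limit of the assay and not a number, so the step has a lower bound but no upper one, and compound 4 joins the other limit values: the limit of > 40000 nM in this assay, at which 3 of the 4 values shown sit.

Still open, from the compounds shown here alone, is whether the activity of compound 1 calls for the vinyl group as such, or whether another group on this carbon, such as an amine, a carboxylic acid or a longer chain, would give a number as well. Within the data shown here, with compound 1 as the only number in the set, the full size of the step and any ordering among the compounds at the limit also remain unresolved.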